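Lengthening the side chain of compound 2

A few compounds are considered here, and "the series" means these few. Any claim that something is new, unique, unknown or untested is made for them only; others in the source may bear on it.

Within the data shown here, in a functional assay on RKO cells (Homo sapiens) for inhibition, read by MTT assay, with a stated time of 48 h (a lower number here means a stronger inhibitor, a higher number a weaker inhibitor), compound 2 (`COc1ccc(N(C)c2nc(C)nc3ccccc23)cc1C(=O)OCC[Se]C#N`) gives 2390 nM, the highest number of the series so far, against compound 1 (`COc1ccc(N(C)c2nc(C)nc3ccccc23)cc1OCCC[Se]C#N`) at 799 nM and compound 3 (`COc1ccc(N(C)c2nc(C)nc3ccccc23)cc1[Se]C`) at 11 nM. Compound 4 (`COc1ccc(N(C)c2nc(C)nc3ccccc23)cc1C(=O)OCCCCCC[Se]C#N`) carries a group of 7 heavy atoms (5 carbon, 1 nitrogen, 1 selenium; no ring) in place of a group of 3 heavy atoms (1 carbon, 1 nitrogen, 1 selenium; no ring), on a saturated chain carbon, two bonds along the chain from an oxygen next to a carbonyl group. Among the measured compounds shown here, no measured step isolates this change. The closest evidence is the modest 3.0-fold higher number from compound 1 to compound 2 (0.48 log units; beyond the scatter), where both side groups are long. The large 73-fold lower number from compound 1 to compound 3 (1.86 log units; beyond the scatter) and a 220-fold lower number from compound 2 to compound 3 (2.34 log units; beyond the scatter) both end in the 2-heavy-atom group, which compound 4 lacks, so they say little here. The expected change is small and only tentatively downward, estimated as a 1.6-fold lower number from compound 2 to compound 4 (0.20 log units; within the scatter). Compound 4 is expected at 1500 nM, with an estimated range of 400 nM to 5000 nM.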

Compound 4, half-maximal inhibitory concentration: 1990 nM
Compound 4: middle estimate off by 1.3-fold (0.12 log units), on the low side; measured number inside the range.
By their numbers in this assay, from the lowest: compound 3; then compound 1; then compounds 4 and 2 (each within the scatter of the next).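

In this assay, a 1.2-fold lower number from compound 2 to compound 4 (0.08 log units; within the scatter) shows that the group of 7 heavy atoms can replace the group of 3 heavy atoms, on a saturated chain carbon, two bonds along the chain from an oxygen next to a carbonyl group, with the step staying within the scatter. Over this pair, the added chain length does not separate the two compounds. No evidence on hand bears on this result.

Going by these compounds, whether a longer chain would also stay within the scatter remains open, as does the outcome with an amine or a carboxylic acid in place of this group.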